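Removing one Methyl from the Pyrazole Amide of Compound 2

A few compounds are considered here, and "the series" means these few. Any claim that something is new, unique, unknown or untested is made for them only; others in the source may bear on it.

Compound 2 `COCCNC(=O)c1c(C)nn(-c2cccc3cc(Cc4cccc(C(F)(F)F)c4)sc23)c1C` is a member of a small set of analogues sharing one core and measured in a functional assay on CHO cells for agonist activity at G-protein coupled receptor 52 (Homo sapiens), read by AlphaScreen and cAMP accumulation, with a stated time of 30 min; on this read-out higher numbers stand for larger maximal responses and lower numbers for smaller maximal responses. Compound 2 gives 104% there. Compound 1 `Cc1nn(-c2cccc3cc(Cc4cccc(C(F)(F)F)c4)sc23)c(C)c1C(=O)NCCO` gives 110%, and a number 6 percentage points lower from compound 1 to compound 2 (within the scatter). Compound 3 `COCCNC(=O)c1cn(-c2cccc3cc(Cc4cccc(C(F)(F)F)c4)sc23)nc1C` gives 89%, and a number 15 percentage points lower from compound 2 to compound 3 (beyond the scatter). Compound 2 thus stands second of the three numbers, within the scatter of compound 1 and beyond it relative to compound 3.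

Compound 4 `COCCNC(=O)c1cnn(-c2cccc3cc(Cc4cccc(C(F)(F)F)c4)sc23)c1C` has not yet been measured in this assay. It differs from compound 2 by hydrogen in place of methyl on an aromatic carbon.

Among the measured compounds shown here, only one measured step speaks to this change. The step from compound 2 to compound 3 also replaces a methyl on an aromatic carbon of the same five-membered ring with hydrogen, though at a different ring carbon, and there a number 15 percentage points lower from compound 2 to compound 3 (beyond the scatter). For the measured compounds named here, no measured step removes the methyl at the position altered in compound 4, so the account of that step is carried over with caution.

On this basis a modest downward step is expected, a number 10 percentage points lower from compound 2 to compound 4 (within the scatter). The maximal response of compound 4 in this assay is therefore estimated at 94%, with a range from 78% to 110%.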

Compound 4, largest response reached (Emax), in percent of the reference or control that the assay uses: 84%
Estimate against measurement, compound 4: 10 percentage points above, and the stated range covers the measured number.
By their numbers in this assay, from the lowest: compounds 4 and 3 (each within the scatter of the next); then compounds 2 and 1 (each within the scatter of the next).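

The methyl on the aromatic carbon next to the ring nitrogen and next to the ring atom that bears the (2-methoxyethyl)carbamoyl group now has a measured step of its own: in this assay, hydrogen in its place gives a number 20 percentage points lower from compound 2 to compound 4 (beyond the scatter) on the maximal response. Among the compounds shown here, the earlier compounds showed such a loss at only one ring carbon, through a number 15 percentage points lower from compound 2 to compound 3 (beyond the scatter), whereas both methyls on this ring have now been replaced singly by hydrogen, and each replacement lowers the response beyond the scatter. Nothing measured here accounts for this step.

On these data alone, what an ethyl group, a chlorine atom or an amine would give on this aromatic carbon remains open, so the compounds do not show whether the response follows the size of the group or depends on the methyl alone. Also open, as far as these compounds go, are the response when hydrogen stands on both ring carbons at once, and whether the same change would lower the response by a similar amount in the hydroxyl-bearing amide of compound 1.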